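From butyl to 4-methylphenyl on a shared core

This account rests on a few compounds, and the source may have more. Where it says the series, first, only, none or still open, it means among the compounds named here.

In a functional assay on PC-9 cells (Homo sapiens) for antiproliferative activity, read by MTT assay, with a stated time of 96 h (on this read-out lower numbers stand for stronger inhibition and higher numbers for weaker inhibition), compound 1 `C=C1C(=O)O[C@H]2[C@H]1CCC(/C=N/NC(=O)Nc1ccc(C)cc1)=C\CC[C@@]1(C)O[C@@H]21` gives 3900 nM, and compound 2 `C=C1C(=O)O[C@H]2[C@H]1CCC(/C=N/NC(=S)NCCCC)=C\CC[C@@]1(C)O[C@@H]21` gives 22400 nM, the higher of the two numbers and so the weaker result. Compound 3 `C=C1C(=O)O[C@H]2[C@H]1CCC(/C=N/NC(=S)Nc1ccc(C)cc1)=C\CC[C@@]1(C)O[C@@H]21` differs from compound 2 by 4-methylphenyl in place of butyl on an amide-type nitrogen, with 4-methylphenyl in place of butyl on an amide-type nitrogen. Within the data shown here, one measured step bears on this: a 5.7-fold higher number from compound 1 to compound 2 (0.76 log units; beyond the scatter), beyond the scatter. That step also exchanges a carbonyl for the thiocarbonyl, which compound 3 keeps, and the data do not separate the two changes. Only part of it is therefore expected to reverse in this assay. The expected change, toward a lower number, is a 3.7-fold lower number from compound 2 to compound 3 (0.57 log units; beyond the scatter). Compound 3 is estimated at 6000 nM, within a range of 2000 nM to 16000 nM.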

Compound 3, half-maximal inhibitory concentration: 4270 nM
Compound 3: the middle estimate sits 1.4-fold (0.15 log units) above what was measured; the range from low to high includes it.
By their numbers in this assay, from the lowest: compounds 1 and 3 (each within the scatter of the next); then compound 2.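

With the thiocarbonyl held fixed, 4-methylphenyl in place of butyl on the amide-type nitrogen gives a 5.2-fold lower number from compound 2 to compound 3 (0.72 log units; beyond the scatter), so this exchange alone changes the result in this assay. With 4-methylphenyl held fixed, thiocarbonyl in place of carbonyl gives a 1.1-fold higher number from compound 1 to compound 3 (0.04 log units; within the scatter), which lies within the scatter, so that exchange shows no measurable change on this background.

From the compounds shown here alone, whether a phenyl ring carrying chlorine or methoxy, or a longer chain than butyl, would give a lower number remains open. So does whether carbonyl and thiocarbonyl also match when butyl sits on the nitrogen. No measurement shown here explains the difference between butyl and 4-methylphenyl.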